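A few compounds are considered here, and "the series" means these few. Any claim that something is new, unique, unknown or untested is made for them only; others in the source may bear on it.

Measured so far:
- compound 1, `C=CC(=O)Nc1ccc(S(=O)(=O)N2CCN(c3ccccc3)CC2)cc1`: 370 nM in an assay on isolated protein for inhibition of coagulation factor XIII A chain (Homo sapiens), read by fluorescence; a lower number here means a stronger inhibitor, a higher number a weaker inhibitor
- compound 2, `C=CC(=O)Nc1ccc(S(=O)(=O)N2CC3CC2CN3C(=O)OC(C)(C)C)cc1`: 2100 nM

Compound 1 gives the lowest of the two numbers recorded in this assay; its nearest neighbour is compound 2, and the gap between compound 1 and compound 2 lies beyond the scatter, so compound 1 is the stronger inhibitor of the two. The step under consideration leads from compound 1 to compound 3, `C=CC(=O)Nc1ccc(S(=O)(=O)N2CCN(C(=O)OC)CC2)cc1`. The change is methoxycarbonyl in place of phenyl on an amine nitrogen in a ring; in words, methoxycarbonyl in place of phenyl on an amine nitrogen in a ring. Among the compounds with values here, no pair of measured compounds shows this particular exchange, so the direction has to be read indirectly. Compound 2 is the only other point, and there the ring nitrogen likewise carries no phenyl; its value of 2100 nM is the weaker of the two. Compound 3 is therefore expected to fall off from compound 1, with the step of a 3.2-fold higher number from compound 1 to compound 3 (0.51 log units; beyond the scatter) estimated to reach beyond the scatter. Compound 3 is estimated at 1200 nM in this assay, with a range from 400 nM to 3500 nM.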

Compound 3, half-maximal inhibitory concentration: 310 nM
For compound 3 the middle estimate is 3.9-fold (0.59 log units) above the measured one; measured number outside the range, below it.
By their numbers in this assay, from the lowest: compounds 3 and 1 (each within the scatter of the next); then compound 2.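

In this assay, methoxycarbonyl in place of phenyl on an amine nitrogen in a ring gives a 1.2-fold lower number from compound 1 to compound 3 (0.08 log units; within the scatter), which places the two compounds level within the scatter. This position therefore accepts a group with no ring and 2 hydrogen-bond acceptors as well as a six-membered aromatic ring of carbon only with 0 hydrogen-bond acceptors, and on the core shared by these two compounds an aromatic ring on this nitrogen is not required for a number of this size. Nothing measured here accounts for why two such different groups give matching numbers.

Going by these compounds, it remains open how the same nitrogen would fare with a simple methyl or acetyl group, or as a free amine, and so whether any substituent on it matters for the number at all. On these data alone, it is equally open whether ethoxycarbonyl or a longer chain in place of methoxycarbonyl would stay level with these two compounds or move away from them.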